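A few compounds are considered here, and "the series" means these few. Any claim that something is new, unique, unknown or untested is made for them only; others in the source may bear on it.

In a functional assay (trachea) for inhibition, with Cavia porcellus as the target (a lower number here means a stronger inhibitor, a higher number a weaker inhibitor), compound 1 `CC1(C)c2ccc([N+](=O)[O-])cc2[C@@H](n2ccccc2=O)[C@@H]1O` gives 150 nM, and compound 2 `CC1(C)C=C(n2ccccc2=O)c2cc([N+](=O)[O-])ccc21` gives 840 nM. Among the compounds with values here, compound 3 `CC1(C)C=C(Cn2ccccc2=O)c2cc(C#N)ccc21` gives > 20000 nM, which is a limit of the assay and not a number, the only such reading among the three. Compound 4 `CC1(C)C=C(CN2CCCC2=O)c2cc(C#N)ccc21` differs from compound 3 by a single change: a group of 6 heavy atoms (4 carbon, 1 nitrogen, 1 oxygen; one five-membered non-aromatic ring with 1 hetero atom) in place of a group of 7 heavy atoms (5 carbon, 1 nitrogen, 1 oxygen; one six-membered aromatic ring with 1 hetero atom), on a saturated chain carbon bound to a double-bonded ring carbon. The 2-oxopyrrolidin-1-yl group enters on a saturated chain carbon bound to a double-bonded ring carbon. Within the data shown here, no measured pair isolates this change, so no step beyond the scatter is expected in this assay, in either direction. The expected step is a number no higher from compound 3 to compound 4 (the limit leaves the size open). Compound 4 is estimated at 20000 nM, with an expected range of 6000 nM to 60000 nM.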

Compound 4, half-maximal inhibitory concentration: 14000 nM
Estimate against measurement, compound 4: 1.4-fold (0.15 log units) above; low and high end bracket the measured number.
By their numbers in this assay, from the lowest: compound 1; then compound 2; then compound 4. At a limit, above all of these: compound 3.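

In this assay, compound 3 gives > 20000 nM, which is a limit and not a number. With the 2-oxopyrrolidin-1-yl group on the saturated chain carbon, compound 4 gives a measurable 14000 nM, and the change reads as an at least 1.4-fold lower number from compound 3 to compound 4 (0.15 log units; that floor lies within the scatter). The true size of this step cannot be read beyond that floor: the limit of > 20000 nM in this assay, at which 1 of the 4 values shown sits.

Within the data shown here, compound 1 and compound 2 differ from compound 4 in more than one place, so no step connects them. Going by these compounds, it remains open whether an amine or a carboxylic acid in this place would change the number beyond the scatter.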